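A few compounds are considered here, and "the series" means these few. Any claim that something is new, unique, unknown or untested is made for them only; others in the source may bear on it.

Measured so far in the series:

compound 1, `COC(=O)C1=C(C)NC(=O)NC1c1ccoc1` — 2%
compound 2, `CCCOC(=O)C1=C(C)NC(=O)NC1c1ccoc1` — 11%
compound 3, `COC(=O)C1=C(C)NC(=S)NC1c1cccs1` — 1%

All three were run in an assay on membranes from HeLa cells for displacement of a labelled ligand from adenosine receptor A3 (Homo sapiens), read by scintillation counting, with a stated time of 180 min, tested at 1 uM; on this read-out higher numbers stand for more inhibition at the one concentration tested (going by the name of the read-out) and lower numbers for less inhibition. Within the data shown here, the one change measured within the set is the extension of the ester on compound 1, giving compound 2: ethyl in place of hydrogen on a saturated chain carbon bound to an oxygen next to a carbonyl group. The step this produced was a number 9 percentage points higher from compound 1 to compound 2 (within the scatter), so on this read-out the longer ester has not moved the signal beyond the noise of the measurement.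

Compound 3 rests on a different core; how the core of compound 3 differs from that of compound 1 is not broken down here. Its value in this assay sits beside the value of compound 1, with nothing between them that exceeds the scatter.

Compound 4, `CCCOC(=O)C1=C(C)NC(=S)NC1c1cccs1`, has not been measured. It carries the same change relative to compound 3 that compound 2 carries relative to compound 1: ethyl in place of hydrogen on a saturated chain carbon bound to an oxygen next to a carbonyl group. The step expected from compound 3 to compound 4 is a number 7 percentage points higher from compound 3 to compound 4 (within the scatter), an estimate resting on the shown step a number 9 percentage points higher from compound 1 to compound 2 (within the scatter) and on the starting value of compound 3, 1%. Compound 4 is therefore expected to give about 8% in this assay, most likely between -4% and 22%.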

Compound 4, a percentage reported as inhibition, at one concentration (the size of the read-out at that concentration, not a potency): 10%
The estimate for compound 4 lay 2 percentage points below the measured number, within the range that was stated.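

In this assay the change from methoxycarbonyl to propoxycarbonyl on the core of compound 3 gives a number 9 percentage points higher from compound 3 to compound 4 (within the scatter). Set beside the same change on the core of compound 1, the two steps do not differ: the same change on two cores in this assay, a number 9 percentage points higher (within the scatter) from compound 1 to compound 2 and a number 9 percentage points higher (within the scatter) from compound 3 to compound 4, 0 percentage points apart, within the scatter of two such steps The agreement shows only that this change gives a step of matching size on these two cores; it does not show that the change has a real effect on either core, as neither step exceeds the scatter and the read-out comes from one concentration.

The compounds shown leave open whether a longer chain on the ester, such as hexyl, a branched group such as isopropyl, or a carboxylic acid in place of the ester would move the signal beyond the scatter. They also leave open whether the match between the two steps would hold on a third core, or for a step large enough to be read clearly.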